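This account rests on a few compounds, and the source may have more. Where it says the series, first, only, none or still open, it means among the compounds named here.

In a physicochemical assay for lipophilicity (on this read-out lower numbers stand for lower lipophilicity and higher numbers for higher lipophilicity), the measured compounds are:
Compound 1 `C[C@H]1CC[C@@H]2[C@@H](OC(=O)[C@]23CC(c2ccccc2)=NO3)[C@]2(C)C(=O)C=C[C@@]12O` with 1.41
Compound 2 `COc1cc(C2=NO[C@]3(C2)C(=O)O[C@@H]2[C@H]3CC[C@H](C)[C@]3(O)C=CC(=O)[C@@]23C)ccc1O` with 0.75
Compound 3 `C[C@H]1CC[C@@H]2[C@@H](OC(=O)[C@]23CC(c2ccccc2F)=NO3)[C@]2(C)C(=O)C=C[C@@]12O` with 1.58

Compound 3 carries the highest number, but without a clear lead over every other compound: the smallest gap is a number 0.17 log units higher from compound 1 to compound 3 (within the scatter), and the largest is a number 0.83 log units higher from compound 2 to compound 3 (beyond the scatter). Compound 4 `C[C@H]1CC[C@@H]2[C@@H](OC(=O)[C@]23CC(c2cccc([N+](=O)[O-])c2)=NO3)[C@]2(C)C(=O)C=C[C@@]12O` has 3-nitrophenyl in place of 2-fluorophenyl on a carbon with a double bond to nitrogen. The nearest guides are swaps at that same carbon. One is the step of a number 0.66 log units lower from compound 1 to compound 2 (beyond the scatter), and the other is the small step already given from fluoro in place of hydrogen. Neither involves 3-nitrophenyl, so only a small downward move in this assay is expected, estimated as a number 0.23 log units lower from compound 3 to compound 4 (within the scatter). For compound 4 the expected value is 1.35, within an estimated range from 0.95 to 1.75.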

Compound 4, partition coefficient: 1.37
The estimate for compound 4 lay 0.02 log units below the measured number; the range from low to high includes it.
By their numbers in this assay, from the lowest: compound 2; then compounds 4, 1 and 3 (each within the scatter of the next).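

In this assay the step of a number 0.04 log units lower from compound 1 to compound 4 (within the scatter) and the step of a number 0.21 log units lower from compound 3 to compound 4 (within the scatter) place 3-nitrophenyl level with phenyl and 2-fluorophenyl on this carbon, so a nitro on the aromatic ring, despite its hydrogen-bond acceptors, reads here like a hydrogen. Only 4-hydroxy-3-methoxyphenyl stands apart, as the step of a number 0.62 log units higher from compound 2 to compound 4 (beyond the scatter) confirms from the other side. No measurement here explains why these groups read as they do. Still open, from the compounds shown here alone, is whether the hydroxy or the methoxy sets compound 2 apart, and where an amine or a carboxylic acid on that ring would fall.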